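Chain lengthening on the aromatic amine: compound 3 to compound 4

A few compounds are considered here, and "the series" means these few. Any claim that something is new, unique, unknown or untested is made for them only; others in the source may bear on it.

All numbers come from an in vitro functional assay on cells for antagonist activity at metabotropic glutamate receptor 1 (Rattus norvegicus), read by inositol phosphate accumulation; a lower number here means a stronger inhibitor, a higher number a weaker inhibitor.

Compound 1 `O=C1CCCc2nc(N3CCN(c4ccccc4)CC3)ccc21`: 10400 nM
Compound 2 `CC1(C)CC(=O)c2cc(C#N)c(NC3CCCCC3)nc2C1`: 4000 nM
Compound 3 `CCCCNc1nc2c(cc1C#N)C(=O)CC(C)(C)C2`: 1700 nM

Compound 3 gives the lowest number of the three. Among the compounds with values here, its nearest neighbour is compound 2 at 4000 nM; compound 1, the only member without the nitrile and with a different amine, stands furthest away at 10400 nM. Both gaps are beyond the scatter, so compound 3 is the strongest inhibitor measured so far.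

Within the data shown here, the one single-point step in the set is a 2.4-fold lower number from compound 2 to compound 3 (0.37 log units; beyond the scatter), a modest gain in the step from a ring to an open chain on the aromatic nitrogen.

Compound 4 `CCCCCCNc1nc2c(cc1C#N)C(=O)CC(C)(C)C2` differs from compound 3 by ethyl in place of hydrogen on a saturated chain carbon, four bonds along the chain from a nitrogen on an aromatic ring. Among the measured compounds shown here, no measured pair shows this kind of extension; the step from compound 2 to compound 3 bears on it only loosely, in that the open butyl chain was tolerated and gave the best number. Nothing here says whether a longer chain helps or hurts, so a step no larger than the modest one already seen, and quite possibly within the scatter, is expected in this assay.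

Compound 4 is therefore estimated at 1200 nM, with a range of 400 nM to 4000 nM; this corresponds to an expected 1.4-fold lower number from compound 3 to compound 4 (0.15 log units; within the scatter).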

Compound 4, half-maximal inhibitory concentration: 2600 nM
For compound 4 the middle estimate is 2.2-fold (0.34 log units) below the measured one; low and high end bracket the measured number.
By their numbers in this assay, from the lowest: compounds 3, 4 and 2 (each within the scatter of the next, the first and the last beyond it); then compound 1.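

In this assay, ethyl in place of hydrogen on a saturated chain carbon, four bonds along the chain from a nitrogen on an aromatic ring, gives a 1.5-fold higher number from compound 3 to compound 4 (0.18 log units; within the scatter) and so leaves butyl and hexyl indistinguishable at this position. Hexyl in place of cyclohexyl gives a 1.5-fold lower number from compound 2 to compound 4 (0.19 log units; within the scatter) while butyl in place of cyclohexyl gives a 2.4-fold lower number from compound 2 to compound 3 (0.37 log units; beyond the scatter) and thus an open chain on this nitrogen does not by itself secure a step beyond the scatter, since only the butyl compound shows one. No accompanying measurement offers an explanation for these results, which stand as a description of the numbers only.

The three open-chain and ring amines shown do not establish how far this position tolerates extension, and an octyl or decyl chain would test whether the flat reading between butyl and hexyl continues. Also open, on these data alone, is whether a chain ending in a hydroxyl, an amine or a carboxylic acid, or a branched chain such as isopentyl, would read differently from the plain butyl and hexyl chains.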